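A few compounds are considered here, and "the series" means these few. Any claim that something is new, unique, unknown or untested is made for them only; others in the source may bear on it.

Measured compounds and their values:

- compound 1 `C#CCN(c1nc(-c2cccc(Br)c2)no1)C1CCCCC1`: 53.5 ug/mL
- compound 2 `CC(=O)OC[C@H]1O[C@H](OC[C@H](Cn2cc(COc3ccc(-c4noc(C)n4)cc3)nn2)OC(C)=O)C=C[C@@H]1OC(C)=O`: 37.7 ug/mL
- compound 3 `CC(=O)OC[C@H]1O[C@H](OC[C@@H](Cn2cc(CN(c3nc(-c4cccc(C)c4)no3)C3CCCCC3)nn2)OC(C)=O)C=C[C@@H]1OC(C)=O`: 39.2 ug/mL

All three were tested in an ADME assay on HepG2 cells (Homo sapiens) for cytotoxicity, read by MTT assay, with a stated time of 48 h; on this read-out lower numbers stand for higher toxicity in this test and higher numbers for lower toxicity in this test. Compound 1 gives the highest of the three numbers, but its gaps to compound 3 and to compound 2 both lie within the usual scatter of such measurements, so the three compounds cannot be told apart on toxicity toward these cells.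

The next compound, compound 4 `C#CCN(c1nc(-c2ccc(Br)cc2)no1)C1CCCCC1`, has the same atoms as compound 1 joined differently: 4-bromophenyl in place of 3-bromophenyl on an aromatic carbon. Going by the values given here, no measured pair in this set shows what such a change does in this assay, so there is nothing to say a shift in either direction should follow. The expectation for compound 4 is therefore a number close to that of compound 1, with the step of a 1.1-fold lower number from compound 1 to compound 4 (0.03 log units; within the scatter) estimated to stay within the scatter. Compound 4 is expected to give about 50 ug/mL, with a range from 25 ug/mL to 100 ug/mL.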

Compound 4, half-maximal cytotoxic concentration: 102 ug/mL
The estimate for compound 4 lay 2.0-fold (0.31 log units) below the measured number; measured number above the stated range.
By their numbers in this assay, from the lowest: compounds 2, 3, 1 and 4 (each within the scatter of the next, the first and the last beyond it).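

Going by these compounds alone, compound 1 and compound 4 form the first pair in this set that differs in only one place, so swapping 3-bromophenyl for 4-bromophenyl on this aromatic carbon can now be read directly in this assay (a 1.9-fold higher number from compound 1 to compound 4 (0.28 log units; within the scatter)). The step stays within the scatter, so the two compounds cannot be told apart on this read-out, and this single pair gives no firm sign that the change affects toxicity toward these cells. Nothing available accounts for the size of the step.

Going by these compounds, it remains open whether a different group in place of the bromine on this phenyl ring, such as an amine or a carboxylic acid, would shift the number beyond the scatter. On these data alone, it is also open whether a similar swap would read the same way on a larger compound such as compound 3.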